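From Dipropylamino to 3-Methylpiperidin-1-yl

The source may report more compounds than this note shows. Statements on the series, on what has been measured and on what is new or still open speak of the compounds shown alone.

Compound 1 `CN(C)c1nc(Cc2c(F)cccc2F)cc(=O)[nH]1`, compound 2 `CC(C)N(C)c1nc(Cc2c(F)cccc2F)cc(=O)[nH]1` and compound 3 `CCCN(CCC)c1nc(Cc2c(F)cccc2F)cc(=O)[nH]1` share a core and differ in the amino group attached to it. In an ADME assay on MT4 cells (Homo sapiens) for cytotoxicity, read by MTT assay, with a stated time of 4 days (a lower number here means that less compound is tolerated, a higher number that more compound is tolerated), compound 1 reads > 94000 nM, which is a limit. Compound 2 gives 85000 nM. Compound 3 reads > 78000 nM, also only a limit. For the measured compounds named here, the one step with a readable floor is an at least 1.1-fold lower number from compound 1 to compound 2 (0.04 log units; that floor lies within the scatter). The others are a step that the two limits leave unreadable from compound 1 to compound 3 and a step that the limit leaves unreadable from compound 2 to compound 3. Compound 4 `CC1CCCN(c2nc(Cc3c(F)cccc3F)cc(=O)[nH]2)C1` carries 3-methylpiperidin-1-yl in place of dipropylamino on an aromatic carbon. With only that small floor to go on, the expected size in this assay is an at least 1.0-fold lower number from compound 3 to compound 4 (0.01 log units; that floor lies within the scatter), nothing beyond the scatter. Compound 4 is estimated at 75000 nM, with an expected range from 35000 nM to 110000 nM.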

Compound 4, half-maximal cytotoxic concentration: > 78000 nM
Compound 4: no number, only a limit; the forecaster's own chance of this, stated with the estimate: 65%; middle value at least 1.0-fold (0.01 log units) away from the limit.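

For the compounds shown here, compound 4 reads > 78000 nM, which is only a limit, so no step from compound 1, compound 2 or compound 3 to compound 4 can be read. Left open is how compound 3 and compound 4 truly compare in this assay, since both give the same limit: the limit of > 78000 nM in this assay, at which 2 of the 4 values shown sit.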